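The source may hold more compounds than are shown below. What is called first, only, known or untested is meant among the compounds shown, and "the series" means these compounds.

Measured in a functional assay on the whole organism with Mus musculus as the target; on this read-out lower numbers stand for an effect already at smaller amounts and higher numbers for an effect only at larger amounts of compound:
- Compound 1 `CCN(CC)C(=O)Cn1c(-c2ccc(Cl)cc2)nc2cccnc21`: 16 mg/kg
- Compound 2 `CN(C)CCNC(=O)Cn1c(-c2ccc(Cl)cc2)nc2cccnc21`: 62 mg/kg

Not yet measured:
- Compound 3 `CN(C)CCN(C)C(=O)Cn1c(-c2ccc(Cl)cc2)nc2cccnc21`

Compound 2, at 62 mg/kg, has the higher of the two numbers in this assay. Compound 3 changes it in one place: methyl in place of hydrogen on an amide-type nitrogen. Among the compounds with values here, only one measured step bears on this, a 3.9-fold higher number from compound 1 to compound 2 (0.59 log units; beyond the scatter). That evidence is indirect: compound 1, like compound 3, has no amide hydrogen, but its amide side chain also differs from that of compound 2. A modest move toward lower numbers is therefore expected, with the estimated change being a 1.6-fold lower number from compound 2 to compound 3 (0.21 log units; within the scatter). The expected value for compound 3 is 38 mg/kg, with an estimated range of 15 mg/kg to 95 mg/kg.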

Compound 3, dose for half-maximal effect: 100 mg/kg
For compound 3 the middle estimate is 2.6-fold (0.42 log units) below the measured one, and the stated range ends below it.
By their numbers in this assay, from the lowest: compound 1; then compounds 2 and 3 (each within the scatter of the next).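

In this assay, methyl in place of hydrogen on the amide-type nitrogen gives a 1.6-fold higher number from compound 2 to compound 3 (0.21 log units; within the scatter), so losing the amide hydrogen does not by itself bring this side chain back to the lower number of compound 1. With that hydrogen gone from both compounds, the gap remains: a 6.3-fold higher number from compound 1 to compound 3 (0.80 log units; beyond the scatter) separates the diethylamino and (2-(dimethylamino)ethyl)(methyl)amino groups on the carbonyl carbon. No measurement shown explains this result.

Still open, as far as these compounds go, is how piperidine on the carbonyl carbon would compare with diethylamino. A longer chain ending in dimethylamino is also untested among these compounds.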